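Removing a Chloro Group: Does Paw Swelling Change?

A few compounds are considered here, and "the series" means these few. Any claim that something is new, unique, unknown or untested is made for them only; others in the source may bear on it.

Of the compounds shown here, two have been measured so far, and a third stands ready. Compound 1 `c1ccc(NCc2nc3ccccc3[nH]2)cc1` is the simplest of the three. In a functional assay on the whole organism (strain albino) for inhibition, with Rattus norvegicus as the target, read by paw edema, with a stated time of 30 min, at a dose of 100 mg/kg by the oral route (on this read-out higher numbers stand for more inhibition at the one dose given (going by the name of the read-out) and lower numbers for less inhibition), compound 1 gives 7.6%. Compound 2 `Clc1cccc(NCc2nc3ccc(Br)cc3[nH]2)c1` carries two halogens, a bromo on the shared core and a chloro on the outer ring. In this assay compound 2 gives 7.6%, level with compound 1 at the digits shown, so the two halogens together leave the read-out unchanged within the usual scatter.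

Compound 3 `Brc1ccc2nc(CNc3ccccc3)[nH]c2c1` keeps the bromo of compound 2 but drops the chloro. The change is hydrogen in place of chloro on an aromatic carbon, on an aromatic carbon of a six-membered aromatic ring of carbon only.

Compound 1 and compound 2 sit at the same low level, and compound 3 lies structurally between them, so no step beyond the scatter is expected in this assay in either direction. The expected step of no change at the digits printed from compound 2 to compound 3 (within the scatter) is small. For compound 3 the estimated read-out in this assay is 7.6%, with a range from 0% to 20%.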

Compound 3, a percentage reported as inhibition, in the whole organism at one dose (the size of the read-out at that dose, not a potency): 7.6%
Beside the measured number, compound 3's estimate shows no gap at the digits printed, within the range that was stated.
By their numbers in this assay, from the lowest: compounds 1, 2 and 3 (each within the scatter of the next).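

Compound 1 and compound 2 differ in two places, so they could only show the bromo and the chloro together, while compound 3 separates the two. In this assay, taking away the chloro from an aromatic carbon of a six-membered aromatic ring of carbon only, and leaving hydrogen there, gives no change at the digits printed from compound 2 to compound 3 (within the scatter), and bromo in place of hydrogen on an aromatic carbon gives no change at the digits printed from compound 1 to compound 3 (within the scatter), so neither single change moves the read-out beyond the scatter, and the level seen for the pair did not hide two large steps pulling against each other. No measurement is at hand that would explain why these read-outs stay level.

All three compounds sit at the same low level in this assay, so these steps say nothing about how the same swaps would behave in a compound with a higher read-out. As far as these compounds go, it also remains open whether a different kind of group on that aromatic carbon, such as an amine, a carboxylic acid or a longer chain, would lift the read-out above the level shared by these three compounds.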